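Changing the sulfur group on a growth inhibitor

The source may hold more compounds than are shown below. What is called first, only, known or untested is meant among the compounds shown, and "the series" means these compounds.

In a functional assay on DU-145 cells (Homo sapiens) for inhibition, read by trypan blue exclusion, with a stated time of 96 h (a lower number here means a stronger inhibitor of growth, a higher number a weaker inhibitor of growth), compound 3 `O=C(/C(=C\c1ccccc1OCc1ccccc1)Sc1ccc(F)cc1)c1ccc(Cl)cc1` gives 1000 nM, level with compound 2 `O=C(/C(=C\c1ccccc1OCc1ccccc1)SCc1ccc(F)cc1)c1ccc(Cl)cc1` at 1000 nM. Within the data shown here, these two share the lowest number so far, whereas compound 1 `Cc1ccc(CS/C(=C/c2ccc(O)cc2)C(=O)c2ccc(Cl)cc2)cc1` gives 10000 nM. Compound 4 `Cc1ccc(CS(=O)(=O)/C(=C/c2ccccc2OCc2ccccc2)C(=O)c2ccc(Cl)cc2)cc1` carries (4-methylbenzyl)sulfonyl in place of (4-fluorophenyl)sulfanyl on a double-bonded chain carbon bound to a carbonyl carbon and a double-bonded chain carbon on the same chain carbon. Among the measured compounds shown here, one measured step bears on this: replacing 4-fluorobenzyl with 4-fluorophenyl on a sulfur gave no change at the digits printed from compound 2 to compound 3 (within the scatter). For the measured compounds named here, no measured compound carries a sulfonyl group, so that part of the change is untested and no direction can be favoured. The expected step is therefore no change at the digits printed from compound 3 to compound 4 (within the scatter), with wide uncertainty. The estimate for compound 4 is 1000 nM, within a range of 150 nM to 7000 nM.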

Compound 4, concentration for 50% growth inhibition: 1000 nM
Beside the measured number, compound 4's estimate shows no gap at the digits printed; the range from low to high includes it.
By their numbers in this assay, from the lowest: compounds 2, 3 and 4 (each within the scatter of the next); then compound 1.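

In this assay, a sulfonyl group on this carbon gives no change at the digits printed from compound 3 to compound 4 (within the scatter). Set against the benzyl sulfur group, the same swap gives no change at the digits printed from compound 2 to compound 4 (within the scatter), so this place accepts a sulfonyl group carrying 4-methylbenzyl with no shift beyond the scatter. No measured evidence explains why the number holds. From the compounds shown here alone, the sulfonyl group and the 4-methylbenzyl group enter together, so their separate effects remain unknown. Also open, going by these compounds, is whether a different group at this place, such as an amine or a carboxylic acid, would keep the same level.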